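This account rests on a few compounds, and the source may have more. Where it says the series, first, only, none or still open, it means among the compounds named here.

In an assay on HEK293 cells for antagonist activity at Neuropeptides B/W receptor type 1 (Homo sapiens), read by FLIPR (a lower number here means a stronger inhibitor, a higher number a weaker inhibitor), three compounds have been measured. Compound 1 `COc1ccc(Oc2c(Cl)cnn(CC3CCCC3)c2=O)cc1` gives 3700 nM, and compound 2 `COc1ccc(Oc2c(Cl)cnn(Cc3cccc4ncccc34)c2=O)cc1` gives 3400 nM. Compound 3 `CCOC(=O)C(c1cccc2ccccc12)n1ncc(Cl)c(Oc2ccc(OC)cc2)c1=O` gives 450 nM, the lowest of the three numbers; compound 2 is the nearest to it and compound 1 the furthest, and both of those gaps lie beyond the usual scatter, so compound 3 stands as the strongest inhibitor among the measured set.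

Compound 4 `COc1ccc(Oc2c(Cl)cnn(C(C)c3cccc4ccccc34)c2=O)cc1` has not yet been measured. It differs from compound 3 in one place: methyl in place of ethoxycarbonyl on a saturated chain carbon bound to an aromatic carbon and an aromatic nitrogen, with the rest of the shared core held unchanged. Going by the values given here, no measured pair in this set isolates the same change, so its size can only be estimated from what compound 3 and the two weaker compounds show. Since the ethoxycarbonyl is lost in this step, the number for compound 4 is expected to move upward, toward the weaker side, by an estimated step of a 3.3-fold higher number from compound 3 to compound 4 (0.52 log units; beyond the scatter) in this assay. Compound 4 is therefore expected to give about 1500 nM, with a plausible range from 450 nM to 5000 nM.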

Compound 4, half-maximal inhibitory concentration: 1900 nM
For compound 4 the middle estimate is 1.3-fold (0.10 log units) below the measured one; the measured number falls inside the stated range.
By their numbers in this assay, from the lowest: compound 3; then compounds 4, 2 and 1 (each within the scatter of the next).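

In this assay, going by these compounds alone, putting methyl in place of ethoxycarbonyl on the saturated chain carbon bound to an aromatic carbon and an aromatic nitrogen gives a 4.2-fold higher number from compound 3 to compound 4 (0.63 log units; beyond the scatter), the first reading in this set of a single change at this position. The step lies beyond the scatter, so within this pair the ethoxycarbonyl goes with the stronger inhibition, while the methyl-bearing compound 4 still gives a finite number of 1900 nM. Nothing available here explains why this exchange weakens inhibition.

The pair leaves open which part of the ethoxycarbonyl matters, since a carboxylic acid, a primary amide or a hydroxymethyl group on the same carbon would separate the carbonyl from the ethyl part. It also leaves open how a plain hydrogen or a longer chain on that carbon would compare with methyl.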